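The source may report more compounds than this note shows. Statements on the series, on what has been measured and on what is new or still open speak of the compounds shown alone.

Working notes on the coumarin propargylamine series.

Two compounds have numbers in an assay on isolated protein for inhibition of Amine oxidase [flavin-containing] B (Homo sapiens), read by fluorescence and Amplex Red, with stated times of 15 min and 20 min (a higher number here means a weaker inhibitor, a lower number a stronger inhibitor), so far. Compound 1 `C#CCN(CCCCOc1ccc2ccc(=O)oc2c1)Cc1cccc(F)c1` gives 1550 nM in this assay. Compound 2 `C#CCN(CCCOc1ccc2ccc(=O)oc2c1)Cc1ccc(F)c(F)c1` gives 4860 nM in this assay. Compound 1 stands with the lower of the two numbers; the gap to compound 2 is beyond the scatter, so compound 1 is the stronger inhibitor of the pair. Compound 2 differs from compound 1 in more than one place, so its number says nothing on its own about any single change.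

The next step goes from compound 1 to compound 3 `C#CCN(C)CCCCOc1ccc2ccc(=O)oc2c1`. The change is hydrogen in place of 3-fluorophenyl on a saturated chain carbon bound to an amine nitrogen. Among the measured compounds shown here, no pair among the measured compounds isolates this change, so the size of the step has to be guessed. The expectation is a clear loss, with the step from compound 1 to compound 3 estimated at a 9.7-fold higher number from compound 1 to compound 3 (0.99 log units; beyond the scatter). On that basis compound 3 is expected to give about 15000 nM in this assay, with a range from 4000 nM to 60000 nM.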

Compound 3, half-maximal inhibitory concentration: 27 nM
Compound 3: the middle estimate sits 560-fold (2.74 log units) above what was measured; measured number outside the range, below it.
By their numbers in this assay, from the lowest: compound 3; then compound 1; then compound 2.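

In this assay, among the compounds shown here, the 3-fluorobenzyl group on the amine nitrogen proves dispensable: with methyl in its place, the single change gives a 57-fold lower number from compound 1 to compound 3 (1.76 log units; beyond the scatter) and is the largest difference seen so far. Compounds 1 and 2 differ in more than one place and could not isolate this position, whereas this pair shows that, on the four-carbon chain of compound 1, inhibition does not depend on the 3-fluorophenyl ring and is much stronger without it. Nothing available on these compounds bears on the origin of this step.

Still open, as far as these compounds go, is whether the gain belongs to methyl itself or simply to the absence of the ring, which an ethyl or cyclopropyl group, or a bare hydrogen, on the same nitrogen would help to separate. Also open, from the compounds shown here alone, is whether the same change carries over to the shorter chain of compound 2, and whether the propargyl group on the nitrogen matters as much once the 3-fluorobenzyl group has gone, for which an allyl or propyl group in its place would be informative.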